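The compounds below may be only part of what the source reports. "The series", "measured", "known", "first", "only" and "open" are said of these compounds alone.

In a functional assay on NCI-H1975 cells (Homo sapiens) for cytotoxicity, read by MTT assay, with a stated time of 72 h (a higher number here means a weaker inhibitor, a lower number a stronger inhibitor), three compounds with a shared core have been measured. Compound 1 `O=C(N/N=C/c1ccccc1)N1CCc2ncnc(Nc3cccc(Br)c3)c2C1` gives 37800 nM, compound 2 `O=C(N/N=C/c1ccc(Br)cc1)N1CCc2ncnc(Nc3cccc(Br)c3)c2C1` gives 51000 nM, and compound 3 `O=C(N/N=C/c1cccs1)N1CCc2ncnc(Nc3cccc(Br)c3)c2C1` gives 122000 nM, the highest number of the three and so the weakest inhibitor among them. Compound 4 `O=C(N/N=C/c1cccnc1)N1CCc2ncnc(Nc3cccc(Br)c3)c2C1` has not yet been measured. It differs from compound 3 as follows: pyridin-3-yl in place of thiophen-2-yl on a carbon with a double bond to nitrogen. Pyridin-3-yl stands in place of thiophen-2-yl on a carbon with a double bond to nitrogen.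

Within the data shown here, two measured steps bear directly on this place, both modest and both ending in thiophen-2-yl: a 3.2-fold higher number from compound 1 to compound 3 (0.51 log units; beyond the scatter) and a 2.4-fold higher number from compound 2 to compound 3 (0.38 log units; beyond the scatter). A third, a 1.3-fold higher number from compound 1 to compound 2 (0.13 log units; within the scatter), stays within the scatter. Leaving thiophen-2-yl for another six-membered aromatic ring might therefore reverse part of those steps, although no pyridine has been measured here. A move to a lower number is expected, no larger than the modest steps already seen. The expected change is a 2.0-fold lower number from compound 3 to compound 4 (0.31 log units; beyond the scatter). For compound 4 the estimated value is 60000 nM, with an expected range from 28000 nM to 130000 nM.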

Compound 4, half-maximal inhibitory concentration: > 200000 nM
Compound 4: only a limit was reported; the forecaster's own chance of this, stated with the estimate: 5%; middle value at least 3.3-fold (0.52 log units) away from the limit.
By their numbers in this assay, from the lowest: compounds 1 and 2 (each within the scatter of the next); then compound 3. At a limit, above all of these: compound 4.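

In this assay, compound 4 is known only as a limit: the limit of > 200000 nM in this assay, at which 1 of the 4 values shown sits. The earlier compounds shown here showed phenyl, 4-bromophenyl and thiophen-2-yl on the carbon with a double bond to nitrogen. Pyridin-3-yl shows that a six-membered aromatic ring alone does not keep the number of the two benzene-based compounds, giving an at least 5.2-fold higher number from compound 1 to compound 4 (0.72 log units; beyond the scatter) and an at least 3.9-fold higher number from compound 2 to compound 4 (0.59 log units; beyond the scatter). Set against thiophen-2-yl, the change gives an at least 1.6-fold higher number from compound 3 to compound 4 (0.21 log units; that floor lies within the scatter), and since that floor lies within the scatter, the limit does not set compound 4 apart from compound 3.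

The compounds shown leave open how far beyond its limit compound 4 lies. They also leave open whether pyridin-2-yl, pyridin-4-yl or a phenyl ring bearing a dimethylamino group would behave as pyridin-3-yl does here.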